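Benzyl ring substitution in the series: towards compound 4

The source may hold more compounds than are shown below. What is called first, only, known or untested is meant among the compounds shown, and "the series" means these compounds.

The three measured compounds share one core and differ only in the aryl group on the saturated chain carbon bound to an oxygen on an aromatic ring. In an assay on lysate for inhibition of phosphatidylcholine:ceramide cholinephosphotransferase 2 (Homo sapiens), read by HPLC, with stated times of 30 min and 2 h (a lower number here means a stronger inhibitor, a higher number a weaker inhibitor), compound 1 `O=C(Nc1cccnc1)c1ccccc1OCc1ccccc1F` gives 3500 nM, the highest number of the three. Compound 2 `O=C(Nc1cccnc1)c1ccccc1OCc1cccc(F)c1` gives 1600 nM, the step being a 2.2-fold lower number from compound 1 to compound 2 (0.34 log units; beyond the scatter). Compound 3 `O=C(Nc1cccnc1)c1ccccc1OCc1c(F)cccc1Cl` gives 1500 nM, with a 2.3-fold lower number from compound 1 to compound 3 (0.37 log units; beyond the scatter). Between compound 2 and compound 3 the step is a 1.1-fold lower number from compound 2 to compound 3 (0.03 log units; within the scatter).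

Compound 4 `Cc1cccc(C)c1COc1ccccc1C(=O)Nc1cccnc1` is not yet measured. Relative to compound 1 it changes as follows: 2,6-dimethylphenyl in place of 2-fluorophenyl on a saturated chain carbon bound to an oxygen on an aromatic ring. Going by the values given here, two measured steps bear on this. The move from compound 1 to compound 2 and the move from compound 1 to compound 3 both lowered the number modestly, each beyond the scatter. Compound 3 is the closer analogue, since its 2-chloro-6-fluorophenyl, like 2,6-dimethylphenyl, carries two groups on the ring; its step of a 2.3-fold lower number from compound 1 to compound 3 (0.37 log units; beyond the scatter) is the main guide. A similar modest decrease is therefore expected, giving a 2.3-fold lower number from compound 1 to compound 4 (0.37 log units; beyond the scatter). Among the compounds with values here, for compound 4 in this assay the estimated value is 1500 nM, expected to fall between 600 nM and 4000 nM; no step within the set suggests a change larger than this, and whether the two methyl groups behave like the two halogens of compound 3 remains to be seen.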

Compound 4, half-maximal inhibitory concentration: 890 nM
Compound 4: the middle estimate sits 1.7-fold (0.23 log units) above what was measured, within the range that was stated.
By their numbers in this assay, from the lowest: compounds 4, 3 and 2 (each within the scatter of the next); then compound 1.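

In this assay, 2,6-dimethylphenyl on a saturated chain carbon bound to an oxygen on an aromatic ring gives (a 3.9-fold lower number from compound 1 to compound 4 (0.59 log units; beyond the scatter)), so an aryl group with neither fluorine nor chlorine also stands clear of compound 1 at this position. Going by these compounds alone, the steps (a 1.7-fold lower number from compound 3 to compound 4 (0.23 log units; within the scatter)) and (a 1.8-fold lower number from compound 2 to compound 4 (0.25 log units; within the scatter)) lie within the scatter, which places compounds 2, 3 and 4 at one level despite their different aryl groups, with 2-fluorophenyl in compound 1 the only group apart from them. No supporting measurement bears on why compound 1 stands apart from the other three.

Still open, as far as these compounds go, is whether a single methyl group on the phenyl ring would sit at the level of 2,6-dimethylphenyl, and whether plain phenyl would sit with compound 1 or with compounds 2, 3 and 4. Also open, from the compounds shown here alone, is how far the number would move with an amine, a carboxylic acid or a methoxy group on this ring in place of the methyl groups, or with a longer chain in place of the saturated chain carbon.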